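A few compounds are considered here, and "the series" means these few. Any claim that something is new, unique, unknown or untested is made for them only; others in the source may bear on it.

For the measured compounds named here, in a physicochemical assay for lipophilicity (a higher number here means a more lipophilic compound, a lower number a more polar compound), compound 2 `O=C(CN(C(=O)c1ccc(-c2ccccn2)cc1)C1CCCCC1)Nc1cc(F)cc(F)c1` gives 3.7, the lower of the two numbers measured so far. Compound 1 `O=C(CN(C(=O)c1ccc(N2CCCC2)cc1)C1CCCCC1)Nc1cc(F)cc(F)c1` gives 4.5. Compound 3 `O=C(CN(CC1CC1)C(=O)c1ccc(-c2ccccn2)cc1)Nc1cc(F)cc(F)c1` has cyclopropylmethyl in place of cyclohexyl on an amide-type nitrogen. Going by the values given here, only one measured step is available, a number 0.80 log units lower from compound 1 to compound 2 (beyond the scatter), and it changed a different place, so it offers a sense of scale and no direct precedent. A fall of similar size is expected here, with fewer carbons in the entering group, and the expected step is a number 0.60 log units lower from compound 2 to compound 3 (beyond the scatter). For compound 3 the estimate is 3.1, within a range of 2.7 to 3.5.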

Compound 3, distribution coefficient: 3.1
Estimate against measurement, compound 3: no gap at the digits printed, within the range that was stated.
By their numbers in this assay, from the lowest: compound 3; then compound 2; then compound 1.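

In this assay, cyclopropylmethyl in place of cyclohexyl on the amide-type nitrogen gives a number 0.60 log units lower from compound 2 to compound 3 (beyond the scatter) in this series. For the compounds shown here, the earlier step, a number 0.80 log units lower from compound 1 to compound 2 (beyond the scatter) at a different place, said nothing about this nitrogen, so this is the first sign that the read-out responds to a change here. No supporting measurement is available to explain the step. As far as these compounds go, with one change at this position, it remains open whether the number simply tracks the size of the group. A longer chain such as n-butyl, or a group carrying an amine or a carboxylic acid, could read quite differently here.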